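From 4-Fluorophenyl to 4-Methoxyphenyl: Estimating Compound 3

This account rests on a few compounds, and the source may have more. Where it says the series, first, only, none or still open, it means among the compounds named here.

Compound 1, `C=CC(=O)Nc1cccc(Nc2nc(N/N=C/c3ccc(F)cc3)ncc2Cl)c1`: 6340 nM
Compound 2, `C=CC(=O)Nc1cccc(Nc2nc(N/N=C(\C)c3ccc(F)cc3)ncc2Cl)c1`: 5050 nM

Both numbers come from an ADME assay on HT-29 cells (Homo sapiens) for inhibition, read by MTT assay, with a stated time of 72 h; a lower number here means a stronger inhibitor, a higher number a weaker inhibitor. Compound 2 holds the lower of the two numbers, yet the step of a 1.3-fold lower number from compound 1 to compound 2 (0.10 log units; within the scatter) lies within the usual scatter, so the two compounds cannot be told apart on this evidence. Compound 3, `C=CC(=O)Nc1cccc(Nc2nc(N/N=C(\C)c3ccc(OC)cc3)ncc2Cl)c1`, is the next step from compound 2; the change is methoxy in place of fluoro on an aromatic carbon. Within the data shown here, no measured step touches this place: the one step known alters the group on a nitrogen on an aromatic ring and leaves the 4-fluorophenyl part untouched. Nothing in the measured pair therefore points to a change beyond the scatter in either direction, and the expectation for compound 3 in this assay is a number close to that of compound 2. The expected step is a 1.0-fold lower number from compound 2 to compound 3 (0.00 log units; within the scatter). Compound 3 is estimated at 5000 nM, with a range from 1500 nM to 16000 nM.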

Compound 3, half-maximal inhibitory concentration: 4560 nM
Estimate against measurement, compound 3: 1.1-fold (0.04 log units) above; the measured number falls inside the stated range.
By their numbers in this assay, from the lowest: compounds 3, 2 and 1 (each within the scatter of the next).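

Among these compounds, this is the first measured change on the aromatic carbon para to a large group, and in this assay the change from 4-fluorophenyl to 4-methoxyphenyl gives a 1.1-fold lower number from compound 2 to compound 3 (0.04 log units; within the scatter). Fluoro and methoxy therefore cannot be told apart at this position in this assay, even though methoxy carries a hydrogen-bond acceptor and fluoro does not. No other measurement is available to account for this result.

From the compounds shown here alone, whether an amine, a carboxylic acid or a longer chain such as butoxy at this place would move the number beyond the scatter remains open. Also open, going by these compounds, is whether the same exchange would read alike on compound 1, where the group on the nitrogen differs from that of compound 2.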